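The source may hold more compounds than are shown below. What is called first, only, known or untested is meant among the compounds shown, and "the series" means these compounds.

Measured compounds:
compound 1 `O=C1C=CC(=O)C(I)=C1` gives 86000 nM in an ADME assay on cells (Peritoneal macrophage, Mus musculus, strain Swiss) for cytotoxicity, with a stated time of 24 h; on this read-out lower numbers stand for higher toxicity in this test and higher numbers for lower toxicity in this test;
compound 2 `O=C1C=CC(=O)C(Br)=C1` gives 34400 nM in this assay;
compound 3 `O=C1C=C(I)C(=O)C(Cl)=C1Cl` gives > 100000 nM in this assay, and this is a limit of the assay rather than a number.

Compound 1 and compound 2 share one core, and the change between them is bromo in place of iodo on a double-bonded ring carbon. That change is measured: a 2.5-fold lower number from compound 1 to compound 2 (0.40 log units; beyond the scatter), so compound 2 is the more toxic of the two in this test.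

Compound 3 has a different core; how it differs from the core of compound 1 is not broken down here. Compound 3 sits at the limit of > 100000 nM in this assay, at which 1 of the 3 values shown sits, so its reading says only that the cells tolerated it up to that point.

Compound 4 `O=C1C=C(Br)C(=O)C(Cl)=C1Cl` has not yet been measured. It differs from compound 3 by bromo in place of iodo on a double-bonded ring carbon. For the measured compounds named here, this is the same kind of change as the one from compound 1 to compound 2, though here the place carries more around it: two ring bonds and three ring bonds away stand ring atoms that each bear a chloro group.

The expectation for compound 4 rests on the step from compound 1 to compound 2 a 2.5-fold lower number from compound 1 to compound 2 (0.40 log units; beyond the scatter), carried over to a compound whose own starting value is only a limit. Compound 4 is therefore estimated at 80000 nM, most likely between 30000 nM and 200000 nM. The step from compound 3 to compound 4 that this estimate means is an at least 1.2-fold lower number from compound 3 to compound 4 (0.09 log units; that floor lies within the scatter), with a real chance that compound 4 also returns only a limit.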

Compound 4, concentration lethal to 50% of the cells: > 100000 nM
Compound 4 was reported as a limit (the forecaster's own chance of this, stated with the estimate: 45%); at least 1.2-fold (0.09 log units) between middle value and limit.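

In this assay, compound 3 and compound 4 each return only a limit of the assay rather than a number, so the step between them cannot be read: the limit of > 100000 nM in this assay, at which 2 of the 4 values shown sit.

The compounds shown leave open whether bromo in place of iodo changes the toxicity in this test at all on the core of compound 3, and whether any such change matches the one seen on the core of compound 1.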